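The compounds below may be only part of what the source reports. "The series", "measured", "known", "first", "only" and "open" are said of these compounds alone.

Working notes on the series.

Compound 1 `O=C(CSc1ncccn1)N/N=c1/scc(-c2ccc(F)cc2)n1-c1ccccc1` is measured in a functional assay on C6 cells (Rattus norvegicus) for cytotoxicity, read by MTT assay, with a stated time of 24 h, tested at 50 ug/mL (on this read-out lower numbers stand for a stronger effect and higher numbers for a weaker effect at the one concentration tested), and gives 55.5%. Among the three numbers in this assay it stands second highest: compound 2 `COc1ccc(-c2cs/c(=N/NC(=O)CSc3ncccn3)n2-c2ccccc2)cc1` gives 66.5%, and compound 3 `COc1ccc(-c2cs/c(=N/NC(=O)CSc3nnc(C)s3)n2-c2ccccc2)cc1` gives 31.5%. The move from compound 1 to compound 2 is a number 11 percentage points higher from compound 1 to compound 2 (beyond the scatter), a modest change; the move from compound 2 to compound 3 is a number 35 percentage points lower from compound 2 to compound 3 (beyond the scatter), a large one.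

Compound 4 `O=C(CSc1nnnn1-c1ccccc1)N/N=c1/scc(-c2ccc(F)cc2)n1-c1ccccc1` is not yet measured in this assay. It differs from compound 1 as follows: 1-phenyl-1H-tetrazol-5-yl in place of pyrimidin-2-yl on a sulfur. For the measured compounds named here, the change of the group on the sulfur is the only kind of change already seen here, the step of a number 35 percentage points lower from compound 2 to compound 3 (beyond the scatter), which lowered the number well beyond the scatter. Going by the values given here, compound 4 replaces the same pyrimidin-2-yl, though with a different group, so a downward step of uncertain size is the expectation, with a wide range because only one such step exists.

For compound 4 the expected value in this assay is 42%, within 25% to 60%. The step from compound 1 is expected to be a number 13.5 percentage points lower from compound 1 to compound 4 (beyond the scatter).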

Compound 4, a percentage reported as activity, at one concentration (the size of the read-out at that concentration, not a potency): 43.7%
Compound 4: the middle estimate sits 1.7 percentage points below what was measured; the measured number falls inside the stated range.
By their numbers in this assay, from the lowest: compound 3; then compound 4; then compound 1; then compound 2.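

In this assay, 1-phenyl-1H-tetrazol-5-yl in place of pyrimidin-2-yl on the sulfur gives a number 11.8 percentage points lower from compound 1 to compound 4 (beyond the scatter). A lower number on leaving pyrimidin-2-yl is therefore seen with the fluoro compound as well as with the methoxy pair, which gave a number 35 percentage points lower from compound 2 to compound 3 (beyond the scatter), and it is not tied to 5-methyl-1,3,4-thiadiazol-2-yl alone, though two steps with two different groups on two different backgrounds make no general rule. No measurement on hand explains the change at this sulfur.

From the compounds shown here alone, it remains open whether 1-phenyl-1H-tetrazol-5-yl gives a similar step when placed on compound 2. Also open, going by these compounds, is whether the lower number needs an aromatic ring on the sulfur at all, which a plain ethyl chain or a carboxylic acid there would test.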